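Dichlorophenyl analogue in the cytotoxicity series

A few compounds are considered here, and "the series" means these few. Any claim that something is new, unique, unknown or untested is made for them only; others in the source may bear on it.

Compound 2 `COc1cccc(/C=C2\CCC/C(=C\c3cccc(Br)c3)C2=O)c1OC` gives 11700 nM in a functional assay on MCF7 cells (Homo sapiens) for cytotoxicity, read by MTT assay, with a stated time of 72 h (a higher number here means a weaker inhibitor, a lower number a stronger inhibitor), the highest of the two numbers shown; its nearest neighbour is compound 1 `COc1cccc(/C=C2\CCC/C(=C\c3ccc(Cl)cc3)C2=O)c1OC` with 10300 nM, a gap that is a 1.1-fold higher number from compound 1 to compound 2 (0.06 log units; within the scatter). Compound 3 `COc1cccc(/C=C2\CCC/C(=C\c3ccc(O)cc3)C2=O)c1OC` gives only a limit, > 20000 nM, see (the limit of > 20000 nM in this assay, at which 1 of the 3 values shown sits). Compound 4 `COc1cccc(/C=C2\CCC/C(=C\c3ccc(Cl)cc3Cl)C2=O)c1OC` differs from compound 2 by 2,4-dichlorophenyl in place of 3-bromophenyl on a double-bonded chain carbon bound to a double-bonded ring carbon. The step that bears on this change is the one between the two halogenated aryl compounds, a 1.1-fold higher number from compound 1 to compound 2 (0.06 log units; within the scatter), which lay within the scatter; the step to the hydroxy compound, an at least 1.7-fold higher number from compound 2 to compound 3 (0.23 log units; that floor lies within the scatter), ends at a limit. A further halogenated phenyl is therefore expected to give no step beyond the scatter, a 1.1-fold lower number from compound 2 to compound 4 (0.03 log units; within the scatter). Compound 4 is estimated at 11000 nM, within 5000 nM to 25000 nM.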

Compound 4, half-maximal inhibitory concentration: > 20000 nM
Compound 4 gave a limit, no number; the forecaster's own chance of this, stated with the estimate: 15%; at least 1.8-fold (0.25 log units) between middle value and limit.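

Compound 4 shows that a halogenated phenyl on this double-bonded chain carbon can also end at the limit of the assay rather than give a number, as the hydroxy compound did: the limit of > 20000 nM in this assay, at which 2 of the 4 values shown sit. Replacing 3-bromophenyl gives an at least 1.7-fold higher number from compound 2 to compound 4 (0.23 log units; that floor lies within the scatter), and the added chloro gives an at least 1.9-fold higher number from compound 1 to compound 4 (0.28 log units; that floor lies within the scatter), so neither change is shown to exceed the scatter. The step between the two limits cannot be read. As far as these compounds go, how far compound 3 and compound 4 lie past the limit stays open, as does whether an amine or a carboxylic acid on this phenyl would give a number.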